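A few compounds are considered here, and "the series" means these few. Any claim that something is new, unique, unknown or untested is made for them only; others in the source may bear on it.

Of the compounds shown here, two that share one core have been tested in an ADME assay on the whole organism for cytotoxicity, with Artemia salina as the target, with a stated time of 24 h; on this read-out lower numbers stand for an effect already at smaller amounts and higher numbers for an effect only at larger amounts of compound. Compound 1 `COc1ccc(/C=C/C(=O)c2ccccc2NC(=O)NS(=O)(=O)c2ccc(C)cc2)cc1` gives 28.1 ug/mL in this assay. Among the compounds with values here, compound 2 `Cc1ccc(S(=O)(=O)NC(=O)Nc2ccccc2C(=O)/C=C/c2ccc(Cl)cc2Cl)cc1` gives 8.34 ug/mL in this assay, which is the lowest of the two numbers, with compound 1 the only neighbour. Within the data shown here, the single measured step is a 3.4-fold lower number from compound 1 to compound 2 (0.53 log units; beyond the scatter). Compound 3 `C=CCOc1ccc(/C=C/C(=O)c2ccccc2NC(=O)NS(=O)(=O)c2ccc(C)cc2)cc1` has not yet been measured; against compound 2 the change is 4-(allyloxy)phenyl in place of 2,4-dichlorophenyl on a double-bonded chain carbon bound to a double-bonded chain carbon. Among the measured compounds shown here, this removes the 2,4-dichlorophenyl that set compound 2 apart and puts in a 4-(allyloxy)phenyl, a group that resembles the 4-methoxyphenyl of compound 1, so the one measured step bears on it, read in reverse. A rise back toward the number of compound 1 is therefore expected, roughly matching that step, namely a 2.9-fold higher number from compound 2 to compound 3 (0.46 log units; beyond the scatter). For compound 3 the value expected in this assay is 24 ug/mL, likely between 11 ug/mL and 50 ug/mL.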

Compound 3, concentration for half-maximal effect: 6.11 ug/mL
Beside the measured number, compound 3's estimate is 3.9-fold (0.59 log units) above it, and the stated range ends above it.
By their numbers in this assay, from the lowest: compounds 3 and 2 (each within the scatter of the next); then compound 1.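

In this assay, the change to 4-(allyloxy)phenyl gives a 1.4-fold lower number from compound 2 to compound 3 (0.14 log units; within the scatter) and so leaves the number where the 2,4-dichlorophenyl put it, which shows that a group without chlorine can do the same at this place. Adding vinyl to the methoxy group gives a 4.6-fold lower number from compound 1 to compound 3 (0.66 log units; beyond the scatter) and is the first sign that a small extension on that oxygen can matter, since the two ethers turn out not to be interchangeable here. Nothing measured explains this result.

The compounds shown leave open whether the vinyl double bond counts or only the longer chain, which a saturated propyl chain on the same oxygen would separate. On these data alone, how an amine such as dimethylamino would behave on that ring also remains open.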